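The source may hold more compounds than are shown below. What is called first, only, known or untested is meant among the compounds shown, and "the series" means these compounds.

In a functional assay on HeLa cells (Homo sapiens) for antiproliferative activity, read by MTT assay, with a stated time of 72 h (on this read-out lower numbers stand for stronger inhibition and higher numbers for weaker inhibition), compound 1 `CC/C=C/C(=O)Nc1cccc(Oc2nc(Nc3ccn(C)n3)nc3c2CSCC3)c1` gives > 50000 nM as a limit and not a number. As far as these compounds go, compound 2 `CC(C)=CC(=O)Nc1cccc(Oc2nc(Nc3ccn(C)n3)nc3c2CSCC3)c1` likewise gives > 50000 nM as a limit and not a number, so its true position is unknown. Compound 3 `CC(C)=CC(=O)Nc1cccc(Oc2nc(Nc3cccc(C#N)c3)nc3c2CSCC3)c1` differs from compound 2 in one place (3-cyanophenyl in place of 1-methyl-1H-pyrazol-3-yl on a nitrogen on an aromatic ring), with 3-cyanophenyl in place of 1-methyl-1H-pyrazol-3-yl on a nitrogen on an aromatic ring. For the measured compounds named here, the only measured step (a step that the two limits leave unreadable from compound 1 to compound 2) lies on a carbonyl carbon rather than on this nitrogen, so it gives no guide to the size of this change. At best a modest gain is expected in this assay because the limit of > 50000 nM in this assay, at which 2 of the 2 values shown sit, offers no measured potency to build on. The estimated change is an at least 1.4-fold lower number from compound 2 to compound 3 (0.15 log units; that floor lies within the scatter) and remains an expectation only. The estimate for compound 3 is 35000 nM (expected range 8000 nM to 80000 nM).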

Compound 3, half-maximal inhibitory concentration: 29200 nM
Compound 3: middle estimate off by 1.2-fold (0.08 log units), on the high side; the measured number falls inside the stated range.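

Placing 3-cyanophenyl in place of 1-methyl-1H-pyrazol-3-yl on this nitrogen gives an at least 1.7-fold lower number from compound 2 to compound 3 (0.23 log units; that floor lies within the scatter) in this assay, and compound 3 holds the only actual number among the compounds shown. Compound 2 has only a limit, so this step is a floor: the real change could be larger, or it could be too small to separate from the scatter. The step on the carbonyl carbon cannot be read, and limits still make up most of the set: the limit of > 50000 nM in this assay, at which 2 of the 3 values shown sit.

The swap changes both the ring and the nitrile together, so the compounds shown do not reveal which of the two goes with the measured number. A plain phenyl group on the same nitrogen would separate the ring from the nitrile, and a but-1-en-1-yl partner for 3-cyanophenyl would test whether the carbonyl side matters.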